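Removing the Nitro Group from an Aryl Sulfonamide

The source may hold more compounds than are shown below. What is called first, only, known or untested is meant among the compounds shown, and "the series" means these compounds.

Compound 3 `Cc1ccc(S(=O)(=O)Nc2cncc(-c3cnc(N)nc3)c2)cc1[N+](=O)[O-]` sits second highest among the three numbers recorded in an assay on isolated protein for binding affinity to phosphatidylinositol 4,5-bisphosphate 3-kinase catalytic subunit beta isoform (Homo sapiens) (on this read-out lower numbers stand for tighter binding and higher numbers for weaker binding), where compound 3 gives 250 nM. Compound 2 `Nc1ncc(-c2cncc(NS(=O)(=O)c3ccc(F)cc3F)c2)cn1` gives 220 nM, a value within the scatter of compound 3, while compound 1 `CS(=O)(=O)Nc1cncc(-c2cnc(N)nc2)c1` gives 5200 nM, far weaker. Compound 4 `Cc1ccc(S(=O)(=O)Nc2cncc(-c3cnc(N)nc3)c2)cc1` differs from compound 3 by hydrogen in place of nitro on an aromatic carbon. Within the data shown here, no measured step removes a substituent from an aromatic ring on the sulfonyl sulfur. Among the measured compounds shown here, the only step known, a 24-fold lower number from compound 1 to compound 2 (1.37 log units; beyond the scatter), shows that putting an aryl group on the sulfonyl sulfur in place of methyl matters greatly, and compound 2 and compound 3 show that two differently substituted aryl groups give numbers within the scatter of each other. Compound 4 keeps the aryl group, so a small step is expected, with a modest weakening of binding as the more likely direction, a 1.6-fold higher number from compound 3 to compound 4 (0.20 log units; within the scatter). Compound 4 is therefore estimated at 400 nM, within a range of 150 nM to 1200 nM in this assay.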

Compound 4, dissociation constant: 100 nM
The estimate for compound 4 lay 4.0-fold (0.60 log units) above the measured number; measured number outside the range, below it.
By their numbers in this assay, from the lowest: compound 4; then compounds 2 and 3 (each within the scatter of the next); then compound 1.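

In this assay, the step on the aromatic ring carried by the sulfonyl sulfur, hydrogen in place of nitro, gives (a 2.5-fold lower number from compound 3 to compound 4 (0.40 log units; beyond the scatter)), so the nitro group is not needed for binding at this carbon and the ring binds more tightly without it. The 4-methylphenyl group now also stands apart from 2,4-difluorophenyl (a 2.2-fold lower number from compound 2 to compound 4 (0.34 log units; beyond the scatter)), although compounds 2 and 3 lay within the scatter of each other, and the step from methyl on the sulfonyl sulfur reaches (a 52-fold lower number from compound 1 to compound 4 (1.72 log units; beyond the scatter)). Nothing in the data shown accounts for these differences.

The compounds shown leave open how an amine or a chlorine at this carbon would compare with hydrogen. They also leave open what the remaining methyl group contributes, which a plain phenyl group on the sulfonyl sulfur would show.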